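This account rests on a few compounds, and the source may have more. Where it says the series, first, only, none or still open, it means among the compounds named here.

Compound 3 `O=C(/C(=C\c1ccc(F)cc1)S(=O)(=O)c1ccc(Br)cc1)c1ccc(Br)cc1` is the starting point. Going by the values given here, in a functional assay on DU-145 cells (Homo sapiens) for inhibition, read by trypan blue exclusion, with a stated time of 96 h (a lower number here means a stronger inhibitor of growth, a higher number a weaker inhibitor of growth), compound 3 gives 4000 nM, the second highest of the three numbers measured so far. Compound 2 `O=C(/C(=C\c1ccc(Br)c([N+](=O)[O-])c1)Sc1ccc(Br)cc1)c1ccc(Br)cc1` gives 1000 nM, a lower number beyond the scatter, and compound 1 `Nc1c(Br)cc(Br)cc1/C=C(\C(=O)c1ccc(Br)cc1)S(=O)(=O)c1ccc(Br)cc1` gives 25000 nM, a higher number beyond the scatter. Among the compounds with values here, the one measured step that touches the same position is a 6.3-fold lower number from compound 1 to compound 3 (0.80 log units; beyond the scatter); it shows that exchanging the group on that chain carbon can move the number well beyond the scatter.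

Compound 4 `O=C(/C(=C\c1ccc(Br)c([N+](=O)[O-])c1)S(=O)(=O)c1ccc(Br)cc1)c1ccc(Br)cc1` has not yet been measured. It differs from compound 3 in a single place: 4-bromo-3-nitrophenyl in place of 4-fluorophenyl on a double-bonded chain carbon bound to a double-bonded chain carbon. Within the data shown here, no measured step makes exactly this exchange. Compound 2 carries the same 4-bromo-3-nitrophenyl group on a different core, and its value lies below that of compound 3 beyond the scatter, which points toward a lower number for compound 4. The step expected from this is a 2.0-fold lower number from compound 3 to compound 4 (0.30 log units; within the scatter), a modest drop rather than a large one. The estimate for compound 4 is 2000 nM, with a range from 600 nM to 8000 nM.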

Compound 4, concentration for 50% growth inhibition: 10000 nM
Compound 4: middle estimate off by 5.0-fold (0.70 log units), on the low side; the whole stated range lies below it.
By their numbers in this assay, from the lowest: compound 2; then compound 3; then compound 4; then compound 1.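

In this assay the 4-bromo-3-nitrophenyl group does not improve on 4-fluorophenyl at this chain carbon of the sulfonyl series, giving a 2.5-fold higher number from compound 3 to compound 4 (0.40 log units; beyond the scatter) for this exchange. The same group still compares well with 2-amino-3,5-dibromophenyl, with a 2.5-fold lower number from compound 1 to compound 4 (0.40 log units; beyond the scatter) in that exchange, so among these three compounds 4-fluorophenyl gives the lowest number and 2-amino-3,5-dibromophenyl the highest. Changing (4-bromophenyl)sulfanyl to (4-bromophenyl)sulfonyl while keeping the 4-bromo-3-nitrophenyl group gives a 10-fold higher number from compound 2 to compound 4 (1.00 log units; beyond the scatter) in this pair, so the low number of compound 2 cannot be credited to the 4-bromo-3-nitrophenyl group alone.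

Still open, on these data alone, is what a plain phenyl or a methoxy-substituted phenyl would give at this chain carbon, and whether a (4-bromophenyl)sulfanyl link would also lower the number with 4-fluorophenyl in place. Nothing available here explains the size or direction of these steps.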